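Changing the sulfur side chain of compound 1

This account rests on a few compounds, and the source may have more. Where it says the series, first, only, none or still open, it means among the compounds named here.

In a functional assay on PC-9 cells (Homo sapiens) for inhibition, read by MTT assay, with a stated time of 72 h (a lower number here means a stronger inhibitor, a higher number a weaker inhibitor), compound 1 `Cc1cc(Nc2cc(-c3ccccc3)[nH]n2)n2nc(SCc3ccc([N+](=O)[O-])cc3)nc2n1` gives 7980 nM. Among the measured compounds shown here, compound 2 `Cc1cc(Nc2ccn(Cc3cccc4ccccc34)n2)n2nc(SCc3ccc(Br)cc3)nc2n1` gives 5660 nM, within the scatter of compound 1, and these are the only two numbers available. Compound 3 `Cc1cc(Nc2ccn(Cc3ccccc3)n2)n2nc(SCc3ccc(Br)cc3)nc2n1` returns only a limit of the assay, > 50000 nM, as noted in the limit of > 50000 nM in this assay, at which 1 of the 3 values shown sits.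

The next comparison is with compound 4 `Cc1cc(Nc2cc(-c3ccccc3)[nH]n2)n2nc(SCCCc3ccccc3)nc2n1`, which carries phenethyl in place of 4-nitrophenyl on a saturated chain carbon bound to a sulfur. For the measured compounds named here, the only measured step, an at least 8.8-fold higher number from compound 2 to compound 3 (0.94 log units; beyond the scatter), is a change elsewhere: phenyl in place of naphthalen-1-yl on a saturated chain carbon bound to an aromatic nitrogen. It shows that one substituent change can move this assay beyond the scatter, but it gives no direction for the sulfur side chain. Going by the values given here, no measured step covers that place, so no shift beyond the scatter is expected, with wide uncertainty either way. The expected change is a 1.1-fold higher number from compound 1 to compound 4 (0.05 log units; within the scatter). Compound 4 is estimated at 9000 nM, with an expected range of 2500 nM to 35000 nM.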

Compound 4, half-maximal inhibitory concentration: 5030 nM
Beside the measured number, compound 4's estimate is 1.8-fold (0.25 log units) above it; the range from low to high includes it.
By their numbers in this assay, from the lowest: compounds 4, 2 and 1 (each within the scatter of the next). At a limit, above all of these: compound 3.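

In this assay, the saturated chain carbon bound to a sulfur now has a measured step of its own: a 1.6-fold lower number from compound 1 to compound 4 (0.20 log units; within the scatter). Among the compounds shown here, the group leaving, 4-nitrophenyl, carries 2 hydrogen-bond acceptors and the group entering, phenethyl, carries 0, so in this pair the number does not depend on those acceptors, whereas the one earlier step, at a different place, lies beyond the scatter. Nothing measured here bears on why this swap leaves the number within the scatter.

As far as these compounds go, whether an amine or a carboxylic acid at the end of the sulfur side chain, or a longer chain, would move the number beyond the scatter remains open. For the compounds shown here, only one pair covers this place, so no trend along the chain can be read from it.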